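A Chloro for a Fluoro: Expected Effect on Cell Inhibition

The source may report more compounds than this note shows. Statements on the series, on what has been measured and on what is new or still open speak of the compounds shown alone.

Compound 1 `Nc1ccccc1NC(=O)c1ccc(CNC(=O)c2n[nH]cc2NC(=O)c2c(F)cccc2Cl)cc1` and compound 2 `Nc1ccccc1NC(=O)c1ccc(CNC(=O)c2n[nH]cc2NC(=O)c2c(Cl)cccc2Cl)cc1` share one core; compound 3 `O=C(NO)c1ccc(CNC(=O)c2n[nH]cc2NC(=O)c2ccccc2F)cc1` and compound 4 `O=C(NO)c1ccc(CNC(=O)c2n[nH]cc2NC(=O)c2ccccc2Cl)cc1` share another, and the difference between the two cores is not broken down here. In a functional assay on SMMC-7721 cells (Homo sapiens) for inhibition, read by CCK-8 assay, with a stated time of 72 h (on this read-out higher numbers stand for weaker inhibition and lower numbers for stronger inhibition), compound 1 gives 16300 nM, compound 2 gives 7760 nM and compound 3 gives 16700 nM. The change from compound 1 to compound 2 is chloro in place of fluoro on an aromatic carbon. That step measured a 2.1-fold lower number from compound 1 to compound 2 (0.32 log units; beyond the scatter). The change from compound 3 to compound 4 is chloro in place of fluoro on an aromatic carbon. It is the same kind of change, though the surroundings differ: in compound 1 the carbon is ortho to a large group and meta to a chloro group, while in compound 3 it is only ortho to a large group. Among the measured compounds shown here, compound 4 is expected to show a similar step, a 1.9-fold lower number from compound 3 to compound 4 (0.27 log units; within the scatter), because the step of a 2.1-fold lower number from compound 1 to compound 2 (0.32 log units; beyond the scatter) is the only guide to this change. Compound 4 is therefore estimated at 9000 nM, within 4000 nM to 20000 nM.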

Compound 4, half-maximal inhibitory concentration: 21800 nM
For compound 4 the middle estimate is 2.4-fold (0.38 log units) below the measured one; measured number above the stated range.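

In this assay, chloro in place of fluoro gives a 1.3-fold higher number from compound 3 to compound 4 (0.12 log units; within the scatter), so on this core the two compounds cannot be told apart. The lower number seen with the same change on the other core therefore did not carry over, and the two steps differ by more than repeat measurements would explain: the same change on two cores in this assay, a 2.1-fold lower number (0.32 log units; beyond the scatter) from compound 1 to compound 2 and a 1.3-fold higher number (0.12 log units; within the scatter) from compound 3 to compound 4, 2.7-fold (0.44 log units) apart, beyond the scatter of two such steps. Among the compounds shown here, this shows that the step cannot simply be transferred between these two cores, but it does not show why, since each core offers only one pair and the cores differ in more than one place.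

Going by these compounds, it remains open whether a bromo or methyl group in the same place would follow either step. The compounds also leave open which part of the difference between the cores sets the size of the step.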